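Stripping one benzyl arm from a well-tolerated amine

This account rests on a few compounds, and the source may have more. Where it says the series, first, only, none or still open, it means among the compounds named here.

Three compounds are known, all built on the same core with an amine carrying two benzyl arms. Compound 1 `CCCCC(c1cc2ccc(C)cc2[nH]c1=O)N(Cc1ccc(F)cc1)Cc1ccc(C(C)C)cc1` is measured in a toxicity assay on MDCK cells (Canis lupus familiaris) for cytotoxicity, read by crystal violet staining, with a stated time of 48 h (a higher number here means that more compound is tolerated, a lower number that less compound is tolerated), where compound 1 gives > 33000 nM, which is a limit of the assay and not a number. Compound 2 `Cc1ccc2cc(CN(Cc3ccc(F)cc3)Cc3ccc(C(C)(C)C)cc3)c(=O)[nH]c2c1` gives > 33000 nM in this assay, again a limit. Compound 3 `Cc1ccc2cc(CN(Cc3ccc(C(C)(C)C)cc3)Cc3cc(F)cc(F)c3)c(=O)[nH]c2c1` gives > 33000 nM in this assay, also a limit.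

Compound 2 therefore stands at the ceiling of what was tested, together with the other two. Going by the values given here, the only single-point step, a step that the two limits leave unreadable from compound 2 to compound 3, cannot be sized because the limit of > 33000 nM in this assay, at which 3 of the 3 values shown sit, holds both of its ends.

Compound 4 `Cc1ccc2cc(CNCc3ccc(F)cc3)c(=O)[nH]c2c1` differs from compound 2 by hydrogen in place of 4-(tert-butyl)benzyl on an amine nitrogen, leaving a secondary amine with one benzyl arm. Among the compounds with values here, no measured step touches this change, and the one measured step gave no readable size, so the evidence supports no particular direction. Compound 4 is expected to remain tolerated up to the limit, with the step that the limit leaves unreadable from compound 2 to compound 4 estimated as none beyond the scatter. Compound 4 is accordingly estimated at 50000 nM, within a range of 20000 nM to 150000 nM.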

Compound 4, half-maximal cytotoxic concentration: > 33000 nM
Compound 4 ended at the assay's limit; the forecaster's own chance of this, stated with the estimate: 85%; the middle value is on the limit's open side.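

In this assay compound 4 gives > 33000 nM, which is a limit of the assay and not a number. No size can be read for the change from compound 2 to compound 4, since both ends are limits: the limit of > 33000 nM in this assay, at which 4 of the 4 values shown sit.

The compounds shown leave open at what concentration any of the four becomes cytotoxic, and whether losing the 4-(tert-butyl)benzyl arm shifts that concentration.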